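Adding one fluoro group to compound 3

The source may hold more compounds than are shown below. What is called first, only, known or untested is meant among the compounds shown, and "the series" means these compounds.

Of the compounds shown here, three sharing one core have numbers so far in a functional assay on MDA-MB-231 cells (Homo sapiens) for antiproliferative activity, read by MTT assay, with a stated time of 24 h (a lower number here means a stronger inhibitor, a higher number a weaker inhibitor), and they differ in the group on the carbonyl carbon. Compound 1 `COC(=O)c1scc(-c2ccc(NC(=O)c3ccccn3)cc2)c1OC` carries pyridin-2-yl and gives 8250 nM as its reading. Compound 2 `COC(=O)c1scc(-c2ccc(NC(=O)c3cccc(C(F)(F)F)c3)cc2)c1OC` carries 3-(trifluoromethyl)phenyl and gives 24600 nM as its reading. Compound 3 `COC(=O)c1scc(-c2ccc(NC(=O)c3cccc(I)c3)cc2)c1OC` carries 3-iodophenyl and gives 8240 nM as its reading. Compound 3 therefore sits level with compound 1, and compound 2 has the higher number, which means the weaker effect.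

Compound 4 `COC(=O)c1scc(-c2ccc(NC(=O)c3cc(I)ccc3F)cc2)c1OC` differs from compound 3 in one place fluoro in place of hydrogen on an aromatic carbon with fluoro in place of hydrogen on an aromatic carbon, so 3-iodophenyl becomes 2-fluoro-5-iodophenyl. Going by the values given here, no measured pair shows the effect of adding fluoro, so the evidence is indirect. Replacing the whole group gave a 3.0-fold higher number from compound 1 to compound 2 (0.47 log units; beyond the scatter) and a 3.0-fold lower number from compound 2 to compound 3 (0.48 log units; beyond the scatter) as modest steps, while the remaining swap gave a 1.0-fold lower number from compound 1 to compound 3 (0.00 log units; within the scatter) as no real change. With steps that small from whole-group swaps, a single added fluoro is expected to shift this assay by no more than the scatter. The expected step is a 1.1-fold higher number from compound 3 to compound 4 (0.04 log units; within the scatter) in this estimate. Compound 4 is estimated at 9000 nM with an expected range from 3500 nM to 23000 nM as its limits.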

Compound 4, half-maximal inhibitory concentration: 16500 nM
Compound 4: middle estimate off by 1.8-fold (0.26 log units), on the low side; low and high end bracket the measured number.
By their numbers in this assay, from the lowest: compounds 3, 1, 4 and 2 (each within the scatter of the next, the first and the last beyond it).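

In this assay, fluoro in place of hydrogen on an aromatic carbon, ortho to a large group and para to an iodo group, now has a direct reading: the change gives a 2.0-fold higher number from compound 3 to compound 4 (0.30 log units; within the scatter), so this single added atom does not move the number beyond the usual scatter. The new compound also blurs a separation seen earlier, since 3-(trifluoromethyl)phenyl and 3-iodophenyl stood apart beyond the scatter, yet 2-fluoro-5-iodophenyl gives a 1.5-fold lower number from compound 2 to compound 4 (0.17 log units; within the scatter) and, against pyridin-2-yl, a 2.0-fold higher number from compound 1 to compound 4 (0.30 log units; within the scatter), which leaves it distinct from neither group. No measurement bears on why the number behaves this way at this position.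

The compounds shown carry only hydrogen or fluoro at this position, so it remains open whether chloro, methyl, methoxy or an amine there would leave the number inside the scatter or push it beyond. As far as these compounds go, it is also open what a hydroxyl group or a carboxylic acid in place of the iodo group would do with the fluoro kept.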